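Trifluoromethyl for methoxy on the anilino ring

The source may hold more compounds than are shown below. What is called first, only, known or untested is meant among the compounds shown, and "the series" means these compounds.

Measured so far in a functional assay on ECa-109 cells for inhibition, with ECa-109 cell line (Homo sapiens) as the target, read by sulforhodamine B assay; on this read-out higher numbers stand for weaker inhibition and lower numbers for stronger inhibition:
compound 1 `COc1ccc(NC2=CC(=O)c3c(nc4n3[C@H]3OC[C@@H](O)[C@H]3OC4)C2=O)cc1`: 3410 nM
compound 2 `COc1cccc(NC2=CC(=O)c3nc4n(c3C2=O)[C@H]2OC[C@@H](O)[C@H]2OC4)c1`: 7620 nM
compound 3 `CCc1ccc(NC2=CC(=O)c3nc4n(c3C2=O)[C@H]2OC[C@@H](O)[C@H]2OC4)cc1`: 3080 nM

Compound 1 sits second highest of the three numbers; compound 3 lies within the scatter of it, while compound 2 gives a higher number beyond the scatter. Going by the values given here, the one step measured so far, a 2.5-fold lower number from compound 2 to compound 3 (0.39 log units; beyond the scatter), swaps the whole anilino substituent rather than one group, so it bears on compound 4 only loosely. Compound 4 `O=C1C(Nc2ccc(C(F)(F)F)cc2)=CC(=O)c2c1nc1n2[C@H]2OC[C@@H](O)[C@H]2OC1` differs from compound 1 by trifluoromethyl in place of methoxy on an aromatic carbon. Among the compounds with values here, no measured step exchanges methoxy for trifluoromethyl, and the anilino changes seen so far are modest, so the expected step of a 1.1-fold lower number from compound 1 to compound 4 (0.06 log units; within the scatter) is small, direction uncertain. Compound 4 is estimated at 3000 nM, range 1200 nM to 8000 nM.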

Compound 4, half-maximal inhibitory concentration: 2250 nM
Compound 4: the middle estimate sits 1.3-fold (0.12 log units) above what was measured, within the range that was stated.
By their numbers in this assay, from the lowest: compounds 4, 3 and 1 (each within the scatter of the next); then compound 2.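

In this assay, going by these compounds alone, the change from 4-methoxyphenyl to 4-(trifluoromethyl)phenyl gives a 1.5-fold lower number from compound 1 to compound 4 (0.18 log units; within the scatter) and is the first exchange read with the rest of the anilino group held constant. The hydrogen-bond acceptor of methoxy goes and the number stays within the scatter, so this position accepts both groups on this read-out. The data give no explanation for this result. Open, as far as these compounds go, is whether an amine, a carboxylic acid or a nitrile in the same place would move the number beyond the scatter. Also open, from the compounds shown here alone, is whether trifluoromethyl behaves the same way when it replaces the methoxy of the 3-methoxyphenyl group in compound 2.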